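This account rests on a few compounds, and the source may have more. Where it says the series, first, only, none or still open, it means among the compounds named here.

Compound 1 `COc1ccc(C2=NN(c3ccccc3)C(c3ccc(C)cc3)C2S(=O)(=O)CC2=NCCO2)cc1` and compound 3 `COc1ccc(C2=NOC(c3ccc(C)cc3)C2S(=O)(=O)CC2=NCCO2)cc1` carry the same group on a saturated chain carbon bound to a sulfonyl sulfur but rest on different cores; the difference between the two cores is not broken down here. In a functional assay, read by Griess assay, with a stated time of 150 min, tested at 50 ug/mL (a higher number here means a stronger effect of the compound at the concentration tested, a lower number a weaker effect), compound 1 gives 59.1%, and in the same assay compound 3 gives 61.9%, two values within the scatter of each other. Compound 2 `COc1ccc(C2=NN(c3ccccc3)C(c3ccc(C)cc3)C2S(=O)(=O)CC2=NCCS2)cc1` differs from compound 1 by a group of 5 heavy atoms (3 carbon, 1 nitrogen, 1 sulfur; one five-membered non-aromatic ring with 2 hetero atoms) in place of a group of 5 heavy atoms (3 carbon, 1 nitrogen, 1 oxygen; one five-membered non-aromatic ring with 2 hetero atoms), on a saturated chain carbon bound to a sulfonyl sulfur. In this assay compound 2 gives 39.4%, and the measured step was a number 19.7 percentage points lower from compound 1 to compound 2 (beyond the scatter). Compound 4 `COc1ccc(C2=NOC(c3ccc(C)cc3)C2S(=O)(=O)CC2=NCCS2)cc1` carries the same change on the core of compound 3: a group of 5 heavy atoms (3 carbon, 1 nitrogen, 1 sulfur; one five-membered non-aromatic ring with 2 hetero atoms) in place of a group of 5 heavy atoms (3 carbon, 1 nitrogen, 1 oxygen; one five-membered non-aromatic ring with 2 hetero atoms), on a saturated chain carbon bound to a sulfonyl sulfur. This change appears twice among the four compounds, once with a measurement. Its place is the same in both pairs, so it is taken as the same change. Among the measured compounds shown here, the step to the unmeasured compound is expected to be of similar size, a number 19.9 percentage points lower from compound 3 to compound 4 (beyond the scatter), resting on the single measured step of a number 19.7 percentage points lower from compound 1 to compound 2 (beyond the scatter). Compound 4 is estimated at 42% in this assay, with a likely range from 28% to 56%.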

Compound 4, a percentage reported as activity, at one concentration (the size of the read-out at that concentration, not a potency): 48.6%
Beside the measured number, compound 4's estimate is 6.6 percentage points below it; measured number inside the range.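

In this assay, the sulfur-containing five-membered ring group in place of the oxygen-containing one on a saturated chain carbon bound to a sulfonyl sulfur again gives a lower read-out, with a number 13.3 percentage points lower from compound 3 to compound 4 (beyond the scatter) on the second core. The two steps point the same way and do not differ in size beyond what repeated measurements allow: the same change on two cores in this assay, a number 19.7 percentage points lower (beyond the scatter) from compound 1 to compound 2 and a number 13.3 percentage points lower (beyond the scatter) from compound 3 to compound 4, 6.4 percentage points apart, within the scatter of two such steps. Among the compounds shown here, this shows that the change carried over between these two cores, but it rests on only two pairs at a single concentration, so it neither establishes the same step on any further core nor explains why the read-out falls.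

The compounds shown leave open what an amine or a carboxylic acid would give in place of either five-membered ring group at this carbon. They also leave open whether the step would hold at other concentrations, where the effect could be stronger or weaker than at the one concentration tested.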